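A few compounds are considered here, and "the series" means these few. Any claim that something is new, unique, unknown or untested is made for them only; others in the source may bear on it.

Compound 2 `CCCc1cc2ccccc2nc1-c1cn(CCC(F)(F)C(F)(F)C(F)(F)C(F)(F)C(F)(F)C(F)(F)C(F)(F)C(F)(F)F)nn1` carries a propyl group on the shared core. In a functional assay on U-937 cells (Homo sapiens) for cytotoxicity, read by MTT assay, with a stated time of 24 h (on this read-out lower numbers stand for stronger inhibition and higher numbers for weaker inhibition), compound 2 gives > 100 ug/mL, which is a limit of the assay rather than a number. Compound 1 `CCCCCc1cc2ccccc2nc1-c1cn(CCC(F)(F)C(F)(F)C(F)(F)C(F)(F)C(F)(F)C(F)(F)C(F)(F)C(F)(F)F)nn1` bears a pentyl group where compound 2 has the propyl. In this assay compound 1 also gives > 100 ug/mL, again a limit and not a number. The step that the two limits leave unreadable from compound 1 to compound 2 therefore cannot be read in size; the limit of > 100 ug/mL in this assay, at which 2 of the 2 values shown sit, tells where both values sit. Compound 3 `CCCCc1cc2ccccc2nc1-c1cn(CCC(F)(F)C(F)(F)C(F)(F)C(F)(F)C(F)(F)C(F)(F)C(F)(F)C(F)(F)F)nn1` has not yet been measured in this assay. It differs from compound 2 by methyl in place of hydrogen on a saturated chain carbon, three bonds along the chain from an aromatic carbon. For the measured compounds named here, the only measured step that bears on this change is the one between compound 1 and compound 2, and its size is not readable. With compound 1 and compound 2 both at the limit, no step beyond the scatter is expected in this assay. The step expected, a step that the limit leaves unreadable from compound 2 to compound 3, would leave compound 3 at the limit as well. Compound 3 is therefore estimated at 150 ug/mL, with a range from 80 ug/mL to 400 ug/mL.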

Compound 3, half-maximal inhibitory concentration: 59.1 ug/mL
Compound 3: the middle estimate sits 2.5-fold (0.40 log units) above what was measured, and the stated range ends above it.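

In this assay, for the compounds shown here, compound 3, with its butyl group, gives 59.1 ug/mL, the only actual number at this position on the shared core. Compound 1 and compound 2 offered only limits, and the step between them cannot be read. Methyl in place of hydrogen on a saturated chain carbon, three bonds along the chain from an aromatic carbon, gives an at least 1.6-fold lower number from compound 2 to compound 3 (0.22 log units; that floor lies within the scatter), and shortening the pentyl group to the butyl group gives an at least 1.6-fold lower number from compound 1 to compound 3 (0.22 log units; that floor lies within the scatter). So this position can carry a chain that reads as a number in this assay, but neither floor establishes a real change, and the butyl group stands alone among limits: the limit of > 100 ug/mL in this assay, at which 2 of the 3 values shown sit.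

As far as these compounds go, it remains open how far the true values of the propyl and pentyl compounds lie from the number for compound 3, and thus whether the butyl group truly stands apart from its two neighbours. The compounds shown also do not tell how an ethyl group, a branched isopropyl group, or a chain ending in an amine or a carboxylic acid would read at this position in this assay.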